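The source may hold more compounds than are shown below. What is called first, only, known or untested is meant among the compounds shown, and "the series" means these compounds.

Measured in an ADME assay on L929 cells (Mus musculus) for cytotoxicity, read by resazurin assay, with a stated time of 96 h (a lower number here means that less compound is tolerated, a higher number that more compound is tolerated), so far:
compound 1 `NC(=S)N/N=C(\COc1ccc(F)c(Cl)c1)c1ccc(Br)cc1` gives 48000 nM
compound 2 `NC(=S)N/N=C(\COc1cccc(Cl)c1)c1ccc(Br)cc1` gives < 50200 nM (a limit)
compound 3 `NC(=S)N/N=C(\COc1ccc(Cl)cc1)c1ccc(Br)cc1` gives < 25100 nM (a limit)

Compound 3 has only the limit < 25100 nM and no number. Compound 4 `NC(=S)N/N=C(\COc1ccc(Cl)c(Cl)c1)c1ccc(Br)cc1` comes from compound 3 through chloro in place of hydrogen on an aromatic carbon and nothing else changes. Going by the values given here, two measured steps bear on this, a step that the limit leaves unreadable from compound 1 to compound 2 and a step that the two limits leave unreadable from compound 2 to compound 3 and neither has a readable size. Among the compounds with values here, compound 1 gives the only number, 48000 nM and it carries fluoro where compound 4 carries chloro. No step beyond the scatter is therefore expected in this assay in either direction. The expected change is a step that the limit leaves unreadable from compound 3 to compound 4 and this is only an estimate. Compound 4 is estimated at 20000 nM with an expected range from 7000 nM to 50000 nM for now.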

Compound 4, half-maximal cytotoxic concentration: 23100 nM
Beside the measured number, compound 4's estimate is 1.2-fold (0.06 log units) below it, and the stated range covers the measured number.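

In this assay, the change at this position, on an aromatic carbon ortho to a chloro group, now has a readable size: with chloro in place of fluoro there is a 2.1-fold lower number from compound 1 to compound 4 (0.32 log units; beyond the scatter). Less compound is tolerated with chloro there than with fluoro. As far as these compounds go, compound 2 and compound 3 carry only limits, and their steps to compound 4 cannot be read, so the size of chloro in place of hydrogen remains unknown.

The compounds shown leave open how a methoxy group or an amine at this position would compare with chloro and fluoro. They also leave open whether this step holds when the bromo group of the shared core is replaced.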